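The source may hold more compounds than are shown below. What is called first, only, known or untested is meant among the compounds shown, and "the series" means these compounds.

For the measured compounds named here, compound 1 `CCCCn1cc(C(=O)C(=O)Nc2ccc(OC)nc2)c2ccccc21` is the only member of this small set with a number in a functional assay on FaDu cells (Homo sapiens) for cytotoxicity, read by MTT assay, with a stated time of 72 h; on this read-out higher numbers stand for lower toxicity in this test and lower numbers for higher toxicity in this test: in this assay compound 1 gives 18 nM. Compound 2 `COc1ccc(NC(=O)C(=O)c2cn(C(C)C)c3cccnc23)cn1` is reported in this assay only as a limit, > 10000 nM. The remaining picture is the limit of > 10000 nM in this assay, at which 2 of the 3 values shown sit. Among the measured compounds, only compound 3 `CCOC(=O)COc1ccc(NC(=O)C(=O)c2cn(CCOC)c3ccccc23)cn1` carries an alkoxy group within its chain, and in this assay compound 3 gives > 10000 nM, which is a limit; it also differs from compound 1 in more than one place, so it offers a hint rather than a measured step. Going by the values given here, no two measured compounds differ in a single place, so no step between them can be read. Compound 4 `COc1ccc(NC(=O)C(=O)c2cn(CCOC(C)C)c3ccccc23)cn1` is the compound still to be tested. It differs from compound 1 by isopropoxy in place of ethyl on a saturated chain carbon, two bonds along the chain from an aromatic nitrogen. With compound 1 standing alone on a number and the others sitting at a limit, the step from compound 1 to compound 4 in this assay is expected to be a loss beyond the scatter, a 14-fold higher number from compound 1 to compound 4 (1.14 log units; beyond the scatter). Compound 4 is accordingly estimated at 250 nM, with a range from 30 nM to 3000 nM.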

Compound 4, concentration lethal to 50% of the cells: 211 nM
Estimate against measurement, compound 4: 1.2-fold (0.07 log units) above, within the range that was stated.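

The series now has its first readable step in this assay (a 12-fold higher number from compound 1 to compound 4 (1.07 log units; beyond the scatter)), and it falls on the chain itself, where isopropoxy takes the place of ethyl on a saturated chain carbon, two bonds along the chain from an aromatic nitrogen. The step shows that this position responds strongly to the change, with a large rise in the number, yet the longer 2-isopropoxyethyl chain does not push compound 4 to the limit of the test. Compound 4 keeps a real number and so stands apart from the limit that holds the other two compounds, which gives the earlier hint from an alkoxy-bearing chain a measured counterpart: the limit of > 10000 nM in this assay, at which 2 of the 4 values shown sit.

The compounds shown do not separate the effect of the oxygen in the chain from that of its branched end, and steps involving the two compounds at the limit cannot be read. As far as these compounds go, how a plain hexyl chain, or an amine or a carboxylic acid at the end of the chain, would read in this assay remains open.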